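Methyl in place of fluoro on the sulfonamide aryl ring

A few compounds are considered here, and "the series" means these few. Any claim that something is new, unique, unknown or untested is made for them only; others in the source may bear on it.

Compound 3 `O=S(=O)(Nc1ccc(Cl)c(F)c1)c1ccc(-c2cnc(C3CC3)o2)cc1` gives 63000 nM in a functional assay on cells (leukaemia cell line, Homo sapiens) for inhibition, read by sulforhodamine B assay, with a stated time of 48 h; a higher number here means a weaker inhibitor of growth, a lower number a stronger inhibitor of growth. Among the three measured compounds it stands second highest: compound 1 `O=S(=O)(Nc1ccc(Cl)c(Cl)c1)c1ccc(-c2cnc(C3CC3)o2)cc1` gives 62100 nM, and the step of a 1.0-fold higher number from compound 1 to compound 3 (0.01 log units; within the scatter) is within the scatter; compound 2 `O=S(=O)(Nc1ccc(Cl)cc1Cl)c1ccc(-c2cnc(C3CC3)o2)cc1` gives 74500 nM, and the step of a 1.2-fold lower number from compound 2 to compound 3 (0.07 log units; within the scatter) is also within the scatter. All three numbers thus sit together. Compound 4 `Cc1cc(NS(=O)(=O)c2ccc(-c3cnc(C4CC4)o3)cc2)ccc1Cl` differs from compound 3 by methyl in place of fluoro on an aromatic carbon. The step that bears on this is a 1.0-fold higher number from compound 1 to compound 3 (0.01 log units; within the scatter), an exchange of one halogen for another on an aromatic carbon, which moved nothing beyond the scatter; the move between 3,4-dichlorophenyl and 2,4-dichlorophenyl, a 1.2-fold higher number from compound 1 to compound 2 (0.08 log units; within the scatter), was likewise flat. The expected step in this assay is therefore none beyond the scatter, no change at the digits printed from compound 3 to compound 4 (within the scatter). Compound 4 is estimated at 63000 nM, within a range of 30000 nM to 130000 nM.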

Compound 4, concentration for total growth inhibition: 33400 nM
Compound 4: the middle estimate sits 1.9-fold (0.28 log units) above what was measured; the range from low to high includes it.
By their numbers in this assay, from the lowest: compounds 4, 1, 3 and 2 (each within the scatter of the next, the first and the last beyond it).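

In this assay, among the compounds shown here, methyl at this position gives the first step beyond the scatter, and a modest one (a 2.2-fold lower number from compound 2 to compound 4 (0.35 log units; beyond the scatter)), but that step exchanges the whole 2,4-dichlorophenyl for 4-chloro-3-methylphenyl. Against the groups on the same carbon, methyl stays within the scatter, both for fluoro (a 1.9-fold lower number from compound 3 to compound 4 (0.28 log units; within the scatter)) and for chloro (a 1.9-fold lower number from compound 1 to compound 4 (0.27 log units; within the scatter)). No measurement shown here accounts for these steps.

As far as these compounds go, whether a methoxy group, an amine or a longer chain on this carbon would move the number beyond the scatter remains open.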